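Two Hydrazide Analogues and a Third Still to Be Tested

The source may report more compounds than this note shows. Statements on the series, on what has been measured and on what is new or still open speak of the compounds shown alone.

Of the compounds shown here, two built on the same core have been measured in a functional assay on MCF7 cells (Homo sapiens) for inhibition, read by sulforhodamine B assay, with a stated time of 48 h; on this read-out higher numbers stand for weaker inhibition of growth and lower numbers for stronger inhibition of growth. Compound 1, with structure `COc1ccc(C(=O)NNC(=O)c2ccc3[nH]c(-c4ccc([N+](=O)[O-])o4)nc3c2)cc1OC`, gives 31.3 ug/mL in this assay. Compound 2, with structure `O=C(NNC(=O)c1cc2ccccc2cc1O)c1ccc2[nH]c(-c3ccc([N+](=O)[O-])s3)nc2c1`, gives 62.5 ug/mL in this assay. Compound 2 carries the highest of the two numbers, but its nearest neighbour is compound 1, and the gap between the two values lies within the usual scatter, so the two cannot be told apart on these data.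

Compound 3, with structure `COc1cccc(C(=O)NNC(=O)c2ccc3[nH]c(-c4ccc([N+](=O)[O-])s4)nc3c2)c1`, has not yet been measured. It differs from compound 2 in one place: 3-methoxyphenyl in place of 3-hydroxynaphthalen-2-yl on a carbonyl carbon. Among the measured compounds shown here, no pair of measured compounds differing in exactly one place is available. For the measured compounds named here, there is no measured step to lean on for this change. The expected step of a 1.6-fold lower number from compound 2 to compound 3 (0.19 log units; within the scatter) is therefore a small one, most likely not beyond the scatter, with a slight lean toward a lower number. Compound 3 is expected to give about 40 ug/mL in this assay, with a plausible range from 15 ug/mL to 110 ug/mL.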

Compound 3, concentration for 50% growth inhibition: 15.6 ug/mL
Compound 3: the middle estimate sits 2.6-fold (0.41 log units) above what was measured; measured number inside the range.
By their numbers in this assay, from the lowest: compounds 3, 1 and 2 (each within the scatter of the next, the first and the last beyond it).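

In this assay, putting 3-methoxyphenyl in place of 3-hydroxynaphthalen-2-yl on a carbonyl carbon gives a 4.0-fold lower number from compound 2 to compound 3 (0.60 log units; beyond the scatter), and this step lies beyond the scatter. The two earlier compounds differ in more than one place, so they could not tie a change in the numbers to any single group; this pair shows that the group on this carbonyl carbon can by itself move the number. In this pair, growth inhibition does not depend on keeping the second aromatic ring or the hydrogen-bond donor of 3-hydroxynaphthalen-2-yl, since the entering group has one six-membered aromatic ring, 0 hydrogen-bond donors and the lower number, although no measurement at hand says which feature of the swap accounts for the step.

On these data alone, the ring, the hydroxyl and the methoxy all change in this one swap, so their separate shares stay unknown, and a plain phenyl, a 3-hydroxyphenyl or a 3-aminophenyl at this place would be needed to pull them apart. As far as these compounds go, whether the same swap gives a similar step on the core of compound 1 also stays open.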